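A few compounds are considered here, and "the series" means these few. Any claim that something is new, unique, unknown or untested is made for them only; others in the source may bear on it.

Compound 2 `COC(=O)/C=C/c1cccc(N(C)C(=O)C2CCCCC2)c1` is the point of departure. In an assay on isolated protein with Bile acid receptor (Homo sapiens) as the target (a lower number here means that less compound is needed, a higher number that more compound is needed for the effect), compound 2 gives > 1000 nM, which is a limit of the assay rather than a number. Compound 1 `COC(=O)/C=C/c1cccc(N(Cc2ccc(-c3c(OC)cccc3OC)cc2)C(=O)C2CCCCC2)c1`, carrying a larger group on the same nitrogen, gives 77 nM in this assay. Compound 3 `COC(=O)/C=C/c1cccc(N(Cc2ccc(C(C)(C)C)cc2)C(=O)C2CCCCC2)c1` has not been measured; it differs from compound 2 by 4-(tert-butyl)phenyl in place of hydrogen on a saturated chain carbon bound to an amide-type nitrogen. A step beyond the scatter toward lower values is expected, an at least 6.6-fold lower number from compound 2 to compound 3 (0.82 log units; beyond the scatter), because compound 2 stands at the limit of > 1000 nM in this assay, at which 1 of the 2 values shown sits. Compound 3 is estimated to give 150 nM, with a range of 40 nM to 600 nM.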

Compound 3, half-maximal effective concentration: > 1000 nM
Compound 3 ended at the assay's limit; the forecaster's own chance of this, stated with the estimate: 15%; middle value at least 6.6-fold (0.82 log units) away from the limit.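

In this assay, the 4-(tert-butyl)phenyl group on the saturated chain carbon bound to an amide-type nitrogen leaves compound 3 at a limit, and the step from compound 2 cannot be read, because both values are limits: the limit of > 1000 nM in this assay, at which 2 of the 3 values shown sit. Tert-butyl in place of 2,6-dimethoxyphenyl on an aromatic carbon gives an at least 12-fold higher number from compound 1 to compound 3 (1.11 log units; beyond the scatter) in this assay, so the large group on that nitrogen does not suffice by itself; its outer part matters. From the compounds shown here alone, whether an unsubstituted phenyl, a single methoxy group, a carboxylic acid or an amine at that outer place would hold the value of compound 1 remains open.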